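A few compounds are considered here, and "the series" means these few. Any claim that something is new, unique, unknown or untested is made for them only; others in the source may bear on it.

Compound 1, `CC1=NN(C(=O)c2cc3ccccc3oc2=O)C(=O)C1CNc1ccccn1`, gives 31.1% in a functional assay on the whole organism for inhibition, with Rattus norvegicus as the target, read by paw edema, with stated times of 1 h and 4 h, at a dose of 0.03 mg/kg by the oral route; on this read-out lower numbers stand for less inhibition and higher numbers for more inhibition at the one dose given (going by the name of the read-out).
Compound 2, `CC1=NN(C(=O)c2cc3ccccc3oc2=O)C(=O)C1CNc1ccc(S(N)(=O)=O)cc1`, gives 68.9% in this assay.
Compound 3, `CC1=NN(C(=O)c2cc3ccccc3oc2=O)C(=O)C1CNc1ccc(Cl)cc1`, gives 43.5% in this assay.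

Among these three, compound 3 stands second highest: it sits a number 12.4 percentage points higher from compound 1 to compound 3 (beyond the scatter), while the step of a number 25.4 percentage points lower from compound 2 to compound 3 (beyond the scatter) places it well under compound 2. The unmeasured compound 4, `CC1=NN(C(=O)c2cc3ccccc3oc2=O)C(=O)C1CNc1ccc(O)c(C(=O)O)c1`, differs from compound 3 in one place: 3-carboxy-4-hydroxyphenyl in place of 4-chlorophenyl on an amine nitrogen.

The step that bears most directly on this change is a number 25.4 percentage points lower from compound 2 to compound 3 (beyond the scatter), where a chloro on the aromatic ring stood in for a group carrying hydrogen-bond donors and acceptors and the number fell. The related step of a number 37.8 percentage points higher from compound 1 to compound 2 (beyond the scatter) points the same way, and a number 12.4 percentage points higher from compound 1 to compound 3 (beyond the scatter) shows that a plain 4-chlorophenyl already gains something over pyridin-2-yl. Since the entering 3-carboxy-4-hydroxyphenyl again brings two hydrogen-bond donors and two acceptors onto the ring, as the sulfamoyl did in compound 2, the step of a number 16.5 percentage points higher from compound 3 to compound 4 (beyond the scatter) is expected to be upward and beyond the scatter, though not necessarily reaching compound 2. Compound 4 is therefore estimated at 60%, within a range from 42% to 78%.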

Compound 4, a percentage reported as inhibition, in the whole organism at one dose (the size of the read-out at that dose, not a potency): 30.9%
Compound 4: the middle estimate sits 29.1 percentage points above what was measured; measured number outside the range, below it.
By their numbers in this assay, from the lowest: compounds 4 and 1 (each within the scatter of the next); then compound 3; then compound 2.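

On the amine nitrogen, 3-carboxy-4-hydroxyphenyl does not repeat the result of 4-sulfamoylphenyl in this assay, even though both bring hydrogen-bond donors and acceptors onto the ring: the result is a number 38 percentage points lower from compound 2 to compound 4 (beyond the scatter), and also a number 12.6 percentage points lower from compound 3 to compound 4 (beyond the scatter), so the presence of donors and acceptors on the ring is not enough on its own to give the high number of compound 2. The step of a number 0.2 percentage points lower from compound 1 to compound 4 (within the scatter) means that this assay does not tell 3-carboxy-4-hydroxyphenyl apart from pyridin-2-yl, so a substituted phenyl ring at this place does not by itself lift the number above that of compound 1. Nothing measured here accounts for these differences, and their origin remains unknown.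

The compounds shown leave open which part of the entering group matters, as the carboxylic acid and the hydroxyl arrive together, and a phenyl ring carrying only one of them, or the methyl ester of the acid, would separate the two. Also open is whether the order among these four groups on the amine nitrogen would hold at other oral doses.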